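This account rests on a few compounds, and the source may have more. Where it says the series, first, only, none or still open, it means among the compounds named here.

Solubility notes on the series. In a physicochemical assay for solubility, measured as kinetic solubility (a higher number here means a more soluble compound, a lower number a less soluble compound), compound 1 `N#Cc1cccc(NC(=O)c2cc(C(F)(F)F)ccc2OCc2ccc(F)cc2)c1` gives < 1000 nM, a limit of the assay rather than a number. Compound 2 `O=C(Nc1cccnc1)c1cc(C(F)(F)F)ccc1OCc1ccccc1` likewise gives < 1000 nM in this assay, again only a limit. Both values therefore sit at the limit of < 1000 nM in this assay, at which 2 of the 2 values shown sit, so compound 2 stands at the floor of what has been resolved here. Compound 3 `O=C(Nc1ccnnc1)c1cc(C(F)(F)F)ccc1OCc1ccccc1` differs from compound 2 as follows: pyridazin-4-yl in place of pyridin-3-yl on an amide-type nitrogen. Within the data shown here, with no measured step to lean on, the step that the limit leaves unreadable from compound 2 to compound 3 is expected to be small, upward if anything, and not clearly beyond the scatter. Compound 3 is thus estimated at 700 nM in this assay, in the range 200 nM to 2500 nM.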

Compound 3, solubility: < 1000 nM
Compound 3: a limit, no number; the forecaster's own chance of this, stated with the estimate: 65%; the middle value does not contradict the limit.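

Compound 2 and compound 3 each give only a limit in this assay, so no step can be read for pyridazin-4-yl in place of pyridin-3-yl: the limit of < 1000 nM in this assay, at which 3 of the 3 values shown sit.

The compounds shown leave open the actual solubility of all three and whether this replacement shifts it.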